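Cyclobutyl on a series still at the assay limit

The compounds below may be only part of what the source reports. "The series", "measured", "known", "first", "only" and "open" are said of these compounds alone.

Of the compounds shown here, two have been measured so far, both in a functional assay on CUTLL1 cells (Homo sapiens) for inhibition, read by resazurin assay, with a stated time of 48 h, in the presence of a further agent that is not named here; a lower number here means that less compound is needed, a higher number that more compound is needed for the effect. Compound 1 (`Cc1nc(N)ncc1-c1ccncc1`) gives > 100000 nM, which is a limit of the assay and not a number. Compound 2 (`Nc1ncc(-c2ccncc2)cn1`) gives > 100000 nM, again a limit. Compound 2 therefore has no numerical standing, and the whole record so far is the limit of > 100000 nM in this assay, at which 2 of the 2 values shown sit. For the measured compounds named here, the one measured step is a step that the two limits leave unreadable from compound 1 to compound 2, so it offers no size to carry forward.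

Compound 3 (`Nc1ncc(-c2ccncc2)c(C2CCC2)n1`) differs from compound 2 by a single change: cyclobutyl in place of hydrogen on an aromatic carbon. Going by the values given here, the only guide is the swap of methyl for hydrogen on an aromatic carbon between compound 1 and compound 2, and that step has no readable size. Any expectation for the cyclobutyl change is therefore loose: a modest shift towards a lower number at best, with a second limit about as likely as a readable value. The expected step is an at least 2.0-fold lower number from compound 2 to compound 3 (0.30 log units; that floor lies within the scatter). For compound 3 the estimated value is 50000 nM, with an expected range of 12000 nM to 100000 nM.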

Compound 3, half-maximal effective concentration: > 100000 nM
Compound 3: no number, only a limit (the forecaster's own chance of this, stated with the estimate: 50%); middle value at least 2.0-fold (0.30 log units) from the limit.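

Compound 3 gives > 100000 nM, which is a limit of the assay and not a number, and neither its step from compound 2 nor its step from compound 1 can be read. The record now stands at a single ceiling: the limit of > 100000 nM in this assay, at which 3 of the 3 values shown sit.

The compounds shown leave open whether any change on the shared core gives a readable value in this assay.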